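The source may hold more compounds than are shown below. What is called first, only, known or untested is meant among the compounds shown, and "the series" means these compounds.

Working notes on the sulfonyl-imide series and a functional assay on RAW264.7 cells (Mus musculus) for inhibition; a higher number here means a weaker inhibitor, a lower number a stronger inhibitor.

Among the compounds with values here, compound 3 `CN(C(=O)OC(C)(C)C)C(=O)c1ccc(CN2C(=O)c3ccccc3S2(=O)=O)cc1` gives 42000 nM in this assay, the highest of the three numbers measured so far. Compound 2 `CNC(=O)c1ccc(CN2C(=O)c3ccccc3S2(=O)=O)cc1` gives 37700 nM, and the step of a 1.1-fold higher number from compound 2 to compound 3 (0.05 log units; within the scatter) stays within the scatter. Compound 1 `CC(C)(C)OC(=O)c1ccc(CN2C(=O)c3ccccc3S2(=O)=O)cc1` gives 10600 nM; the step of a 4.0-fold higher number from compound 1 to compound 3 (0.60 log units; beyond the scatter) and the step of a 3.6-fold higher number from compound 1 to compound 2 (0.55 log units; beyond the scatter) are both beyond the scatter, in the weakening direction.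

Compound 4 `CC(C)(C)OC(=O)N(Cc1ccco1)C(=O)c1ccc(CN2C(=O)c3ccccc3S2(=O)=O)cc1` differs from compound 3 by furan-2-yl in place of hydrogen on a saturated chain carbon bound to an amide-type nitrogen, or, cut one bond further out, methyl to (furan-2-yl)methyl. Within the data shown here, the only measured step at that part of the molecule, the step from compound 2 to compound 3 with its a 1.1-fold higher number from compound 2 to compound 3 (0.05 log units; within the scatter), was within the scatter, so growth on the amide-type nitrogen has so far left this assay largely unmoved. The other two steps concern the carbonyl carbon and do not bear directly on this change.

Expected for compound 4: a step of a 1.1-fold higher number from compound 3 to compound 4 (0.03 log units; within the scatter), that is, no change beyond the scatter. The estimate for compound 4 in this assay is 45000 nM, with a range from 15000 nM to 130000 nM.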

Compound 4, half-maximal inhibitory concentration: 2610 nM
Beside the measured number, compound 4's estimate is 17-fold (1.24 log units) above it; measured number below the stated range.
By their numbers in this assay, from the lowest: compound 4; then compound 1; then compounds 2 and 3 (each within the scatter of the next).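

In this assay the amide-type nitrogen is not the silent place it seemed: the change from methyl to (furan-2-yl)methyl gives a 16-fold lower number from compound 3 to compound 4 (1.21 log units; beyond the scatter), a large step towards stronger inhibition, whereas adding tert-butoxycarbonyl on that nitrogen gave only a 1.1-fold higher number from compound 2 to compound 3 (0.05 log units; within the scatter). Substitution at this position can therefore move the read-out strongly, and furan-2-yl on the saturated chain carbon bound to that nitrogen does so, although this rests on a single step. Nothing measured here explains the size or direction of this step.

As far as these compounds go, whether the gain is particular to furan-2-yl stays open, as does what phenyl, thiophen-2-yl or a longer alkyl chain on that carbon would give. Also open, from the compounds shown here alone, is whether (furan-2-yl)methyl would keep this effect with the amide hydrogen in place of tert-butoxycarbonyl.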